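The compounds below may be only part of what the source reports. "The series", "measured", "known", "first", "only" and "open" are said of these compounds alone.

Of the compounds shown here, two have been measured in a functional assay on cells (Splenocyte, Mus musculus, strain BALB/c) for inhibition, read by scintillation counting and thymidine incorporation, with stated times of 48 h and 8 h; on this read-out higher numbers stand for weaker inhibition and lower numbers for stronger inhibition. Compound 1, `Clc1ccc(-c2noc(Cc3c[nH]c4ccccc34)n2)cc1`, gives 22600 nM. Compound 2, `COc1cc(-c2noc(-c3ccc(NC(=O)OC(C)(C)C)cc3)n2)cc(OC)c1OC`, gives 1600 nM. On these two numbers compound 2 stands lowest, and its nearest neighbour is compound 1, whose number is higher by an amount that lies beyond the scatter of this assay. For the measured compounds named here, the two compounds share their core but differ from each other in several places at once, so no single step between them can be read off.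

Compound 3, `CCc1ccc(-c2nc(-c3cc(OC)c(OC)c(OC)c3)no2)cc1`, has not yet been measured. It is derived from compound 2 by a single change: ethyl in place of (tert-butoxycarbonyl)amino on an aromatic carbon. Going by the values given here, no step between measured compounds shows how this kind of change moves the number, so the expectation rests on compound 2 alone. A shift in this assay of no more than modest size is expected, with the direction uncertain. The expected step is a 1.9-fold higher number from compound 2 to compound 3 (0.27 log units; within the scatter). Compound 3 is therefore estimated at 3000 nM, with a range from 600 nM to 15000 nM.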

Compound 3, half-maximal inhibitory concentration: > 50000 nM
Compound 3: no number, only a limit (the forecaster's own chance of this, stated with the estimate: 5%); middle value at least 16-fold (1.22 log units) away from the limit.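

In this assay compound 3 gives > 50000 nM, which is a limit of the assay and not a number. Placing ethyl where (tert-butoxycarbonyl)amino stood, on the aromatic carbon para to a large group, gives an at least 31-fold higher number from compound 2 to compound 3 (1.49 log units; beyond the scatter), so this position is far from indifferent to what it carries, and this particular exchange costs much of the inhibition seen with compound 2. The size of that step is a lower bound and not a measurement, and the true gap could be larger still: the limit of > 50000 nM in this assay, at which 1 of the 3 values shown sits.

The change removes 8 heavy atoms, including a hydrogen-bond donor and 2 hydrogen-bond acceptors, and brings in only 2 carbons, so the compounds shown cannot tell which part of the (tert-butoxycarbonyl)amino group matters for the number, or whether its size or its atoms count. A plain amine or an acetamide at this position, or a longer chain such as butyl, would begin to separate these possibilities, and the reason for the loss remains open for now.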